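Compound 1 to compound 3: one added methoxy

A few compounds are considered here, and "the series" means these few. Any claim that something is new, unique, unknown or untested is made for them only; others in the source may bear on it.

Going by the values given here, compound 1 (`COc1ccc2[nH]cc(/C=C(\C#N)C(=O)c3c[nH]c4ccccc34)c2c1`) holds the only number so far: in a functional assay on MIA PaCa-2 cells (Homo sapiens) for cytotoxicity, read by WST assay, with a stated time of 48 h (a higher number here means a weaker inhibitor, a lower number a stronger inhibitor), compound 1 gives 25100 nM. Compound 2 (`N#C/C(=C\c1c[nH]c2ccc(Br)cc12)C(=O)c1c[nH]c2ccc(Br)cc12`) gives only a limit, recorded as > 50000 nM. Among the compounds with values here, compound 1 and compound 2 differ in more than one place, and one number set against one limit gives no measured step to work from.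

Compound 3 (`COc1ccc2[nH]cc(/C=C(\C#N)C(=O)c3c[nH]c4ccc(OC)cc34)c2c1`) keeps the core of compound 1 and changes it in one place: methoxy in place of hydrogen on an aromatic carbon. This is methoxy in place of hydrogen on an aromatic carbon. Within the data shown here, the series contains no measured example of this change, so the expectation rests on compound 1 at 25100 nM. In this assay, no step beyond the scatter is expected, and no direction is favoured. The estimated step, a 1.1-fold lower number from compound 1 to compound 3 (0.06 log units; within the scatter), is therefore expected to be small. A report of only a limit, as with compound 2, remains possible. The expected value for compound 3 is 22000 nM, with an estimated range of 8000 nM to 50000 nM.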

Compound 3, half-maximal inhibitory concentration: > 50000 nM
Compound 3 was reported as a limit (the forecaster's own chance of this, stated with the estimate: 25%); at least 2.2-fold (0.35 log units) between middle value and limit.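

In this assay, going by these compounds alone, methoxy in place of hydrogen on an aromatic carbon gives the first step that can be read, an at least 1.9-fold higher number from compound 1 to compound 3 (0.29 log units; that floor lies within the scatter), and it runs toward the higher number. Compound 3 gives > 50000 nM, which is a limit of the assay and not a number, so the step has a floor but no measured size, and that floor does not by itself separate the pair beyond the scatter. At this place, para to a fused ring, the added methoxy therefore brings no gain over hydrogen, and how much is lost cannot be told, with the reading of compound 3 sitting at the same ceiling as most of the series: the limit of > 50000 nM in this assay, at which 2 of the 3 values shown sit.

The compounds shown leave open whether any group at this aromatic carbon can bring the number below that of compound 1, 25100 nM, since only hydrogen and methoxy can be compared here. An amine, a carboxylic acid or a longer chain such as propoxy at this carbon would test whether the trend belongs to methoxy alone or to substitution at this place in general.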